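The source may report more compounds than this note shows. Statements on the series, on what has been measured and on what is new or still open speak of the compounds shown alone.

Measured compounds:
Compound 1 `CCCSc1nc(Cl)c2c(n1)N(Cc1ccccc1)C(C(=O)N1CCN(C)CC1)N2`: > 64000 nM
Compound 2 `CCCSc1nc(Cl)c2c(n1)N(CCNC(=O)OC(C)(C)C)C(C(=O)N1CCN(C)CC1)N2`: 59300 nM

In a functional assay on MGC-803 cells (Homo sapiens) for antiproliferative activity, read by MTT assay, with a stated time of 72 h (a lower number here means a stronger inhibitor, a higher number a weaker inhibitor), compound 1 gives only a limit, > 64000 nM, which is the limit of > 64000 nM in this assay, at which 1 of the 2 values shown sits. Compound 2 gives 59300 nM in this assay, and the step of an at least 1.0-fold lower number from compound 1 to compound 2 (0.03 log units; that floor lies within the scatter). Compound 3 `CCCSc1nc(Cl)c2c(n1)N(Cc1ccccc1)C(C(=O)NCCCc1ccccc1)N2` differs from compound 1 by (3-phenylpropyl)amino in place of 4-methylpiperazin-1-yl on a carbonyl carbon. For the measured compounds named here, no measured step touches that part of the molecule; the one known step alters a different position and stays within the scatter. For compound 3 the step of an at least 1.2-fold lower number from compound 1 to compound 3 (0.10 log units; that floor lies within the scatter) is therefore expected to be small. Compound 3 is estimated at 50000 nM, in a range from 15000 nM to 150000 nM.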

Compound 3, half-maximal inhibitory concentration: 16900 nM
Compound 3: the middle estimate sits 3.0-fold (0.47 log units) above what was measured; the measured number falls inside the stated range.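

On the carbonyl carbon, replacing 4-methylpiperazin-1-yl with (3-phenylpropyl)amino gives an at least 3.7-fold lower number from compound 1 to compound 3 (0.57 log units; beyond the scatter). Unlike the earlier step at the other position, this one goes beyond the scatter, so the group on the carbonyl carbon can change antiproliferative activity. The true step may be larger, since compound 1 gives a limit and not a number: the limit of > 64000 nM in this assay, at which 1 of the 3 values shown sits.

Still open, from the compounds shown here alone, is which part of the new group matters: its terminal phenyl ring, its chain length or its amide hydrogen. A plain propylamino group, lacking the ring, or a shorter benzylamino group could help separate these.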